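Swapping the aryl group on the aromatic nitrogen

A few compounds are considered here, and "the series" means these few. Any claim that something is new, unique, unknown or untested is made for them only; others in the source may bear on it.

In a functional assay on T47D cells (Homo sapiens) for antiproliferative activity, read by MTT assay, with a stated time of 72 h (a higher number here means a weaker inhibitor, a lower number a stronger inhibitor), compound 1 `COc1cc(-c2nccn2C)cc(OC)c1OC` reaches only a limit of the assay, > 100000 nM. Compound 2 `CCCCCn1ccnc1-c1cc(OC)c(OC)c(OC)c1` gives 64400 nM. Compound 3 `COc1cc(-c2nccn2-c2cccc(C)c2)cc(OC)c1OC` gives 29300 nM, the lower of the two actual numbers, and it is the starting point here.

Compound 4 `COc1cc(-c2nccn2-c2ccc(F)cc2)cc(OC)c1OC` is still unmeasured. It differs from compound 3 as follows: 4-fluorophenyl in place of 3-methylphenyl on an aromatic nitrogen. The swap therefore places 4-fluorophenyl in place of 3-methylphenyl, while the shared core stays the same.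

Within the data shown here, two measured steps bear on this only indirectly, since both introduce the 3-methylphenyl group in place of an alkyl group: an at least 3.4-fold lower number from compound 1 to compound 3 (0.53 log units; beyond the scatter) and a 2.2-fold lower number from compound 2 to compound 3 (0.34 log units; beyond the scatter). Among the measured compounds shown here, both are small, and no measured step exchanges one substituted phenyl for another. With the aryl group kept in compound 4, no clear shift in either direction is expected from compound 3 at 29300 nM.

The expected change is a 1.0-fold higher number from compound 3 to compound 4 (0.01 log units; within the scatter), not beyond the scatter. Compound 4 is estimated at 30000 nM, with an expected range of 11000 nM to 80000 nM.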

Compound 4, half-maximal inhibitory concentration: > 100000 nM
Compound 4 ended at the assay's limit (the forecaster's own chance of this, stated with the estimate: 12%); middle value at least 3.3-fold (0.52 log units) from the limit.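

In this assay, the aryl group on the aromatic nitrogen proves not to be freely interchangeable: 4-fluorophenyl in place of 3-methylphenyl gives an at least 3.4-fold higher number from compound 3 to compound 4 (0.53 log units; beyond the scatter), so the lower number seen with 3-methylphenyl does not carry over to every substituted phenyl group. Against the alkyl group, 4-fluorophenyl in place of pentyl gives an at least 1.5-fold higher number from compound 2 to compound 4 (0.19 log units; that floor lies within the scatter), which means that an aryl group at this position does not by itself give the lowest number. Compound 4 stops at a limit of the assay, and its step with compound 1 cannot be read since both values are limits: the limit of > 100000 nM in this assay, at which 2 of the 4 values shown sit.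

As far as these compounds go, whether the step follows from the fluorine or from the loss of the methyl group stays open. So does how an unsubstituted phenyl or a chlorophenyl group on the same nitrogen would read.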